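From 3-Bromobenzyl to Propargyl on a Shared Core

A few compounds are considered here, and "the series" means these few. Any claim that something is new, unique, unknown or untested is made for them only; others in the source may bear on it.

Measured in an ADME assay on GES1 cells (Homo sapiens) for inhibition, read by MTT assay, with a stated time of 72 h; on this read-out lower numbers stand for stronger inhibition and higher numbers for weaker inhibition:
- Compound 1 `Cc1cc(Nc2cc(-c3ccccc3)[nH]n2)n2nc(SCc3c(Cl)cccc3Cl)nc2n1`: 39600 nM
- Compound 2 `Cc1cc(Nc2cc(-c3ccccc3)[nH]n2)n2nc(SCC(=O)c3ccccc3)nc2n1`: 33300 nM
- Compound 3 `Cc1cc(Nc2cc(-c3ccccc3)[nH]n2)n2nc(SCc3cccc(Br)c3)nc2n1`: > 50000 nM, a limit and not a number

Compound 3 has no exact value and sits at the limit of > 50000 nM in this assay, at which 1 of the 3 values shown sits. Compound 4 `C#CCSc1nc2nc(C)cc(Nc3cc(-c4ccccc4)[nH]n3)n2n1` keeps the shared core and differs from compound 3 in one place: ethynyl in place of 3-bromophenyl on a saturated chain carbon bound to a sulfur. Ethynyl stands in place of 3-bromophenyl on a saturated chain carbon bound to a sulfur, so that 3-bromobenzyl gives way to propargyl.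

The three measured steps all fall at this same place. Benzoyl in place of 2,6-dichlorophenyl gives a 1.2-fold lower number from compound 1 to compound 2 (0.08 log units; within the scatter). 3-Bromophenyl in place of 2,6-dichlorophenyl gives an at least 1.2-fold higher number from compound 1 to compound 3 (0.10 log units; that floor lies within the scatter). 3-Bromophenyl in place of benzoyl gives an at least 1.5-fold higher number from compound 2 to compound 3 (0.17 log units; that floor lies within the scatter). Only the first of these joins two exact numbers, and the other two are floors. Within the data shown here, none of the measured compounds carries ethynyl at this place, so the evidence is indirect. Among the measured compounds shown here, with a 1.2-fold lower number from compound 1 to compound 2 (0.08 log units; within the scatter) as the one exact step, no change beyond the scatter is expected in this assay, in either direction.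

The estimated step is an at least 1.1-fold lower number from compound 3 to compound 4 (0.04 log units; that floor lies within the scatter).

For compound 4 the expected value is 45000 nM, with an estimated range of 25000 nM to 80000 nM.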

Compound 4, half-maximal inhibitory concentration: 45700 nM
Compound 4: the middle estimate sits 1.0-fold (0.01 log units) below what was measured; the measured number falls inside the stated range.
By their numbers in this assay, from the lowest: compounds 2, 1 and 4 (each within the scatter of the next). At a limit, above all of these: compound 3.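

Compound 4 is the only compound shown whose group on the saturated chain carbon bound to a sulfur has no ring, and in this assay ethynyl leaves the number within the scatter of both exact earlier compounds: a 1.4-fold higher number from compound 2 to compound 4 (0.14 log units; within the scatter), and a 1.2-fold higher number from compound 1 to compound 4 (0.06 log units; within the scatter). Benzoyl, 2,6-dichlorophenyl and ethynyl thus give exact numbers that do not separate at this place, while the change from 3-bromophenyl can be read only as a floor, an at least 1.0-fold lower number from compound 3 to compound 4 (0.03 log units; that floor lies within the scatter). Compound 3 holds a limit and not a number: the limit of > 50000 nM in this assay, at which 1 of the 4 values shown sits.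

From the compounds shown here alone, how far the true value of compound 3 lies from its limit remains open, so the size of the change from 3-bromobenzyl to propargyl is not settled. Also open, going by these compounds, is whether an amine, a carboxylic acid or a longer chain on this saturated chain carbon would move the number in this assay beyond the scatter.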